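A few compounds are considered here, and "the series" means these few. Any claim that something is new, unique, unknown or untested is made for them only; others in the source may bear on it.

Compound 1 `CCc1cccc(NC(=O)c2cccc(/C=C3\CC(=O)N(Cc4ccccc4)C3=O)c2)c1` and compound 2 `Cc1ccc(NC(=O)c2cccc(/C=C3\CC(=O)N(c4ccccc4)C3=O)c2)cc1C` share the same core and were both tested in an ADME assay on SW480 cells (Homo sapiens) for cytotoxicity, read by MTT assay, with a stated time of 72 h; on this read-out higher numbers stand for weaker inhibition and lower numbers for stronger inhibition. In this assay compound 1 gives 91500 nM, a weak result. For compound 2 the assay reports > 100000 nM, which is a limit of the assay and not a measured number. Compound 2 thus stands at the limit of > 100000 nM in this assay, at which 1 of the 2 values shown sits, so the numbers show only that it is no stronger than that boundary.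

Compound 3 `O=C(Nc1ccc(F)cc1)c1cccc(/C=C2\CC(=O)N(c3ccccc3)C2=O)c1` has not yet been measured in this assay. It differs from compound 2 in one place: 4-fluorophenyl in place of 3,4-dimethylphenyl on an amide-type nitrogen. For the measured compounds named here, with no step between two measured compounds to lean on, the expectation rests on the two weak values above. In this assay the change from compound 2 to compound 3 is expected to be small, not beyond the usual scatter, in either direction; the expected step is an at least 1.1-fold lower number from compound 2 to compound 3 (0.04 log units; that floor lies within the scatter). Compound 3 is therefore estimated at 90000 nM, with a range from 30000 nM to 250000 nM, and a fair chance that the assay again reports only a limit.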

Compound 3, half-maximal inhibitory concentration: > 100000 nM
Compound 3: only a limit was reported; the forecaster's own chance of this, stated with the estimate: 50%; at least 1.1-fold (0.04 log units) between middle value and limit.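

Compound 2 and compound 3 both give only a limit in this assay and no number, so the step between them cannot be read: the limit of > 100000 nM in this assay, at which 2 of the 3 values shown sit.

Going by these compounds, what stays open is how far either compound lies past that limit, and whether 4-fluorophenyl in place of 3,4-dimethylphenyl on an amide-type nitrogen changes the result in this assay at all.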